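Amide aryl variation on the shared core: toward compound 3

This account rests on a few compounds, and the source may have more. Where it says the series, first, only, none or still open, it means among the compounds named here.

Two compounds with the same core are in hand. Compound 1 `NC(=O)c1c(NC(=O)c2ccccc2Cl)sc2c1CCN(C(=O)Nc1ccccc1Cl)C2` gives 12500 nM in a functional assay on HL-60 cells (Homo sapiens) for antiproliferative activity, with a stated time of 24 h; on this read-out lower numbers stand for stronger inhibition and higher numbers for weaker inhibition. Compound 2 `Cc1ccc(C(=O)Nc2sc3c(c2C(N)=O)CCN(C(=O)Nc2ccccc2Cl)C3)cc1` gives 14600 nM in this assay; this is the higher of the two numbers, but the step of a 1.2-fold higher number from compound 1 to compound 2 (0.07 log units; within the scatter) lies within the scatter, so compounds 1 and 2 cannot be told apart on this read-out.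

Compound 3 `NC(=O)c1c(NC(=O)c2cccc([N+](=O)[O-])c2)sc2c1CCN(C(=O)Nc1ccccc1Cl)C2` has not yet been measured. It differs from compound 2 by 3-nitrophenyl in place of 4-methylphenyl on a carbonyl carbon. Among the measured compounds shown here, the only measured step that bears on this place is a 1.2-fold higher number from compound 1 to compound 2 (0.07 log units; within the scatter), where one aryl group on the carbonyl carbon was exchanged for another without moving the number beyond the scatter. For the measured compounds named here, no compound with 3-nitrophenyl at this position has been measured, so nothing beyond that single step informs the expectation.

On that basis the step from compound 2 to compound 3 is expected to be small, a 1.0-fold lower number from compound 2 to compound 3 (0.02 log units; within the scatter), with no direction beyond the scatter. Compound 3 is therefore estimated at 14000 nM in this assay, within a range of 5000 nM to 40000 nM.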

Compound 3, half-maximal inhibitory concentration: 18500 nM
Estimate against measurement, compound 3: 1.3-fold (0.12 log units) below; the measured number falls inside the stated range.
By their numbers in this assay, from the lowest: compounds 1, 2 and 3 (each within the scatter of the next).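

In this assay, the place on the carbonyl carbon whose other neighbours are the amide-type nitrogen now has a third aryl group, and 3-nitrophenyl, with 2 hydrogen-bond acceptors against 0 for 4-methylphenyl, gives a 1.3-fold higher number from compound 2 to compound 3 (0.10 log units; within the scatter) and, against the 2-chlorophenyl of compound 1, a 1.5-fold higher number from compound 1 to compound 3 (0.17 log units; within the scatter) as the widest step in the set. The earlier pair showed only one exchange at this place, whereas the three compounds now give three pairs, and none of the three steps leaves the scatter, even with nitrogen and oxygen atoms entering the group, so no aryl group shown here can be told apart from another on this read-out. No evidence is at hand that would account for this flat result.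

Still open, as far as these compounds go, is whether a group of another kind on this carbonyl carbon, such as a short alkyl chain, or a phenyl carrying an amine or a carboxylic acid, would move the number beyond the scatter. Also open, from the compounds shown here alone, is whether any change outside this place, on the rest of the shared core, would shift the number at all.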